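Removing One Fluoro Group: Expected Effect on Cytotoxicity

This account rests on a few compounds, and the source may have more. Where it says the series, first, only, none or still open, it means among the compounds named here.

Of the compounds shown here, three have been tested in a functional assay on CCRF-CEM cells (Homo sapiens) for cytotoxicity, in the absence of a further agent; on this read-out lower numbers stand for stronger inhibition and higher numbers for weaker inhibition. Compound 1 `Nc1nc(N)c(CCCNc2cc(F)ccc2[N+](=O)[O-])c(O)n1` gives only a limit of the assay, > 100000 nM. Compound 2 `Nc1nc(N)c(CCCNc2cc(F)cc(F)c2[N+](=O)[O-])c(O)n1` gives 97000 nM. Compound 3 `CC(C)(C)OC(=O)CCC(Nc1ccc(CN(CCCc2c(N)nc(N)nc2O)c2cc(F)cc(F)c2[N+](=O)[O-])cc1)C(=O)OC(C)(C)C` gives 13000 nM, the lowest number among the measured compounds.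

Compound 1 differs from compound 2 by hydrogen in place of fluoro on an aromatic carbon. This gave an at least 1.0-fold higher number from compound 2 to compound 1 (0.01 log units; that floor lies within the scatter), and compound 1 sits at the limit of > 100000 nM in this assay, at which 1 of the 3 values shown sits, so the change is not seen to alter the read-out beyond the scatter. How the core of compound 3 differs from that of compound 2 is not broken down here.

Compound 4 `CC(C)(C)OC(=O)CCC(Nc1ccc(CN(CCCc2c(N)nc(N)nc2O)c2cc(F)ccc2[N+](=O)[O-])cc1)C(=O)OC(C)(C)C` has not yet been measured. It differs from compound 3 by hydrogen in place of fluoro on an aromatic carbon, the same change as between compound 2 and compound 1. Because the earlier step of an at least 1.0-fold higher number from compound 2 to compound 1 (0.01 log units; that floor lies within the scatter) stayed within the scatter, a similarly small step is expected from compound 3 to compound 4, a 1.2-fold higher number from compound 3 to compound 4 (0.06 log units; within the scatter). Compound 4 is therefore estimated at about 15000 nM in this assay, with a likely range from 6000 nM to 40000 nM.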

Compound 4, half-maximal inhibitory concentration: 8700 nM
Compound 4: middle estimate off by 1.7-fold (0.24 log units), on the high side; the range from low to high includes it.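

On the core of compound 3, hydrogen in place of fluoro gives a 1.5-fold lower number from compound 3 to compound 4 (0.17 log units; within the scatter) in this assay, so on this core the change does not move the read-out beyond the scatter. Set beside the earlier step, this result does not show that the change acts alike on both cores: the same change on two cores in this assay, an at least 1.0-fold higher number (0.01 log units; that floor lies within the scatter) from compound 2 to compound 1 and a 1.5-fold lower number (0.17 log units; within the scatter) from compound 3 to compound 4; the limit leaves it open whether they differ. Compound 1 gives > 100000 nM, which is a limit of the assay.

The compounds shown leave open whether a different group in place of this fluoro, such as a chlorine atom, a methoxy group or an amine, would shift the read-out. They also leave open how the change would behave with carboxylic acids in place of the two esters.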